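The source may hold more compounds than are shown below. What is called first, only, known or untested is meant among the compounds shown, and "the series" means these compounds.

Of the compounds shown here, three of this set have been measured. Compound 1 `O=C1C=COC(/C=C/c2ccccc2)C1` gives 58.2 uM in a functional assay on OVCAR-3 cells (Homo sapiens) for inhibition, read by sulforhodamine B assay, with a stated time of 48 h; on this read-out lower numbers stand for stronger inhibition of growth and higher numbers for weaker inhibition of growth. Compound 2 `COc1ccc(/C=C/C2CC(=O)C=CO2)cc1` carries the change methoxy in place of hydrogen on an aromatic carbon and gives 87.4 uM; the step of a 1.5-fold higher number from compound 1 to compound 2 (0.18 log units; within the scatter) is small. Compound 3 `COc1ccc(/C=C/c2cc(=O)cco2)cc1` gives 328 uM, the highest of the three numbers, and its distance from both compound 2 and compound 1 lies beyond the scatter. The difference between the core of compound 3 and the core of compound 1 is not broken down here.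

Compound 4 `COc1ccc(/C=C/c2cc(=O)cco2)cc1OC` has not yet been measured. It differs from compound 3 by methoxy in place of hydrogen on an aromatic carbon. This is the same kind of change as that from compound 1 to compound 2, but the surroundings differ: in compound 2 the methoxy sits para to a group of 9 heavy atoms, whereas in compound 4 it sits ortho to a methoxy group (2 heavy atoms) and meta to a group of 9 heavy atoms.

Because a 1.5-fold higher number from compound 1 to compound 2 (0.18 log units; within the scatter) was within the scatter, the step of a 1.2-fold higher number from compound 3 to compound 4 (0.06 log units; within the scatter) is expected to be small as well. Compound 4 is therefore estimated at 380 uM, with a likely range from 150 uM to 950 uM in this assay.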

Compound 4, concentration for growth inhibition (reported as GI): 540 uM
Compound 4: the middle estimate sits 1.4-fold (0.15 log units) below what was measured, within the range that was stated.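

In this assay, methoxy in place of hydrogen on an aromatic carbon again gives only a small step on the core of compound 3, which is a 1.6-fold higher number from compound 3 to compound 4 (0.22 log units; within the scatter). Set beside the earlier case, the same change gives steps of matching size on the two cores: the same change on two cores in this assay, a 1.5-fold higher number (0.18 log units; within the scatter) from compound 1 to compound 2 and a 1.6-fold higher number (0.22 log units; within the scatter) from compound 3 to compound 4, 1.1-fold (0.04 log units) apart, within the scatter of two such steps. For the compounds shown here, this shows that the change carried over from one core to the other with little effect on the read-out, even though the new methoxy stands ortho to a methoxy group in compound 4, but with only two pairs and both steps within the scatter, it does not show that the same would hold on a further core or at another place on the aromatic ring.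

The compounds shown leave open whether a different group at this place, such as a hydroxyl, an amine or a carboxylic acid, would give a step beyond the scatter. They also leave open what a longer chain in place of the methoxy would give on either core.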